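Notes on compound 4: methyl removed from the aromatic oxygen

The compounds below may be only part of what the source reports. "The series", "measured", "known", "first", "only" and "open" are said of these compounds alone.

Measured in an assay for inhibition of ribonucleoside-diphosphate reductase RR1 (Homo sapiens), with a stated time of 30 min; a higher number here means a weaker inhibitor, a lower number a stronger inhibitor:
- compound 1 `Oc1ccc(/C=N/NC(=S)Nc2ccccc2Cl)cc1`: 46800 nM
- compound 2 `Oc1ccc(/C=N/NC(=S)Nc2cccc(Cl)c2)cc1`: 29300 nM
- compound 3 `COc1ccccc1NC(=S)N/N=C/c1ccc(O)cc1`: 41600 nM

Compound 3 stands second highest of the three numbers; compound 1 lies within the scatter of it, and compound 2 sits furthest off, still within the scatter. Compound 4 `Oc1ccc(/C=N/NC(=S)Nc2ccccc2O)cc1` differs from compound 3 by hydrogen in place of methyl on an oxygen on an aromatic ring, cut one bond further out methoxy to hydroxy. Among the compounds with values here, the only single-point step measured, a 1.1-fold lower number from compound 1 to compound 3 (0.05 log units; within the scatter), is within the scatter. Within the data shown here, no measured step removes a methyl from an aromatic oxygen, and compound 2 is not a single-point neighbour of compound 3. With only a within-scatter step in hand, no move beyond the scatter is expected in this assay. Compound 4 is therefore estimated at 35000 nM, range 15000 nM to 80000 nM. The expected step is a 1.2-fold lower number from compound 3 to compound 4 (0.08 log units; within the scatter).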

Compound 4, half-maximal inhibitory concentration: 29300 nM
Estimate against measurement, compound 4: 1.2-fold (0.08 log units) above; the range from low to high includes it.
By their numbers in this assay, from the lowest: compounds 2, 4, 3 and 1 (each within the scatter of the next).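

In this assay hydrogen in place of methyl on an oxygen on an aromatic ring gives a 1.4-fold lower number from compound 3 to compound 4 (0.15 log units; within the scatter) and hydroxy in place of chloro gives a 1.6-fold lower number from compound 1 to compound 4 (0.20 log units; within the scatter) at the same place. Chloro, methoxy and hydroxy at this place are therefore not told apart by this read-out, and the free hydroxy brings no step beyond the scatter. No evidence is available on what lies behind these small steps. As far as these compounds go, whether an amine or a carboxylic acid at this place would move the number beyond the scatter stays open, as do changes elsewhere on the shared core.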